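Hydroxy to Nitro: Expected Cytotoxicity of Compound 3

The compounds below may be only part of what the source reports. "The series", "measured", "known", "first", "only" and "open" are said of these compounds alone.

Two compounds have been measured in an ADME assay on Vero cells (Chlorocebus sabaeus) for cytotoxicity; on this read-out lower numbers stand for stronger inhibition and higher numbers for weaker inhibition:

Compound 1, `COc1ccc(Cn2cc(CNC(=O)c3ccc([N+](=O)[O-])o3)nn2)cc1O`: 174000 nM
Compound 2, `COc1cc(Cn2cc(CNC(=O)c3ccc([N+](=O)[O-])o3)nn2)ccc1O`: 224000 nM

Compound 1 and compound 2 share one core and differ only in the arrangement of a hydroxy and a methoxy group on the outer ring. Their numbers sit close together: a 1.3-fold higher number from compound 1 to compound 2 (0.11 log units; within the scatter), so on this read-out the two cannot be told apart. Among the compounds with values here, compound 1 is therefore the reference, with compound 2 as its only neighbour.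

Compound 3, `COc1ccc(Cn2cc(CNC(=O)c3ccc([N+](=O)[O-])o3)nn2)cc1[N+](=O)[O-]`, has not yet been measured. It differs from compound 1 in one place: nitro in place of hydroxy on an aromatic carbon. Within the data shown here, no measured step covers a nitro group entering where a hydroxy group stood; the single measured step, from compound 1 to compound 2, concerns a different change and stays within the scatter. With nothing in the numbers pointing either way, the estimate for compound 3 in this assay is 174000 nM, with a range from 70000 nM to 430000 nM. This expected step is no change at the digits printed from compound 1 to compound 3 (within the scatter), no larger than the scatter.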

Compound 3, half-maximal inhibitory concentration: 176000 nM
Compound 3: the middle estimate sits 1.0-fold (0.00 log units) below what was measured; low and high end bracket the measured number.
By their numbers in this assay, from the lowest: compounds 1, 3 and 2 (each within the scatter of the next).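

In this assay, nitro in place of hydroxy on this aromatic carbon, ortho to a methoxy group, gives a 1.0-fold higher number from compound 1 to compound 3 (0.00 log units; within the scatter) as its step. The earlier pair only exchanged the arrangement of hydroxy and methoxy on the outer ring, with both groups kept, whereas this step removes the hydroxy altogether: 1 heavy atom and 1 hydrogen-bond donor give way to 3 heavy atoms and 0 hydrogen-bond donors, and this read-out shows no difference that can be told from scatter. No measured information available here accounts for this result.

The compounds shown leave open whether an amine, a carboxylic acid or a longer chain such as ethoxy on this same aromatic carbon would also stay within the scatter of compound 1. They also leave open whether nitro in place of hydroxy would give a similar step in the arrangement of compound 2, where the hydroxy and methoxy groups have exchanged places on the outer ring.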